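A few compounds are considered here, and "the series" means these few. Any claim that something is new, unique, unknown or untested is made for them only; others in the source may bear on it.

Measured in a functional assay on MCF7 cells (Homo sapiens) for cytotoxicity, read by MTT assay, with a stated time of 72 h, tested at 1 uM; a higher number here means more inhibition of growth at the concentration tested, a lower number less inhibition of growth:
compound 1 `N/C(=N\NC(=S)N1CCOCC1)c1ccccn1` gives 14.7%
compound 2 `Cc1cccc(/C(N)=N/NC(=S)N2CCSCC2)n1` gives 7.3%

Among the measured compounds shown here, compound 2 stands at one of only two numbers, and the gap to compound 1 is within the usual scatter, so the two cannot be told apart. Compound 3 `Cc1cccc(/C(N)=N/NC(=S)N2CCOCC2)n1` differs from compound 2 in one place: morpholin-4-yl in place of thiomorpholin-4-yl on a thiocarbonyl carbon. For the measured compounds named here, no step between measured compounds isolates this exchange; the nearest hint is compound 1, which carries the same morpholin-4-yl and gives 14.7%. The expected step, a number 3.7 percentage points higher from compound 2 to compound 3 (within the scatter), is none beyond the scatter. Compound 3 is therefore estimated at 11%, within a range of 2% to 22%.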

Compound 3, percent growth inhibition at one concentration: 11.7%
Compound 3: middle estimate off by 0.7 percentage points, on the low side; measured number inside the range.
By their numbers in this assay, from the lowest: compounds 2, 3 and 1 (each within the scatter of the next).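

In this assay the exchange of thiomorpholin-4-yl for morpholin-4-yl on a thiocarbonyl carbon can now be read directly, as a number 4.4 percentage points higher from compound 2 to compound 3 (within the scatter) and so the two rings cannot be told apart at this place. Methyl in place of hydrogen on an aromatic carbon also gets its own step, a number 3 percentage points lower from compound 1 to compound 3 (within the scatter) and this change likewise separates nothing. Nothing measured here accounts for either step. On these data alone, whether a piperidin-1-yl ring or an open dimethylamino group on the thiocarbonyl carbon would move the number beyond the scatter remains open. The same holds for a methoxy group or a chlorine atom in place of that methyl.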